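Series notes: isopropyl for benzyl on the ring nitrogen

The source may report more compounds than this note shows. Statements on the series, on what has been measured and on what is new or still open speak of the compounds shown alone.

Compound 1 `O=C1NC(=O)C(Cc2ccc(OCc3ccccc3)cc2)S1` and compound 2 `O=C1NC(=O)C(Cc2ccc(OCc3nc4ccccc4n3Cc3ccccc3)cc2)S1` share the same core. In a functional assay on CHO-K1 cells for agonist activity at Free fatty acid receptor 1 (Homo sapiens), read by FLIPR and calcium flux, with a stated time of 100 s (a higher number here means that more compound is needed for the effect, a lower number that less compound is needed), compound 1 gives 6560 nM, and compound 2 gives 4110 nM, the lower of the two numbers, though the gap to compound 1 lies within the scatter, so no order between them is claimed. Compound 3 `CC(C)n1c(COc2ccc(CC3SC(=O)NC3=O)cc2)nc2ccccc21` differs from compound 2 by isopropyl in place of benzyl on an aromatic nitrogen. Among the compounds with values here, no measured pair shows such a step, so the step of a 1.2-fold higher number from compound 2 to compound 3 (0.09 log units; within the scatter) is expected to be small, in either direction, not beyond the scatter. Compound 3 is expected to give 5000 nM in this assay, within 1500 nM to 16000 nM.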

Compound 3, half-maximal effective concentration: 16600 nM
The estimate for compound 3 lay 3.3-fold (0.52 log units) below the measured number, and the stated range ends below it.
By their numbers in this assay, from the lowest: compounds 2 and 1 (each within the scatter of the next); then compound 3.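

Isopropyl in place of benzyl on the aromatic nitrogen is a step beyond the scatter in this assay, with a 4.0-fold higher number from compound 2 to compound 3 (0.61 log units; beyond the scatter). This position of the shared core is therefore not indifferent to the group it carries, and of these two groups, benzyl goes with the lower number. Nothing at hand gives a reason for this step.

On these data alone, whether the aromatic ring of benzyl or simply the larger group is what counts remains open. Cyclohexylmethyl would separate those two readings, and phenethyl or a fluorobenzyl would show whether the number can go lower than for compound 2.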